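A Second Chlorine Placement on the Fluorosulfonyl Ring

The compounds below may be only part of what the source reports. "The series", "measured", "known", "first", "only" and "open" are said of these compounds alone.

Within the data shown here, compound 1 `CC1(C)N=C(N)N=C(N)N1c1ccc(OCc2cccc(S(=O)(=O)F)c2)c(Cl)c1` stands highest of the two numbers so far in an assay on isolated protein for inhibition of Dihydrofolate reductase (Mus musculus) (a lower number here means a less potent compound, a higher number a more potent compound, by a factor of ten per unit of this negative logarithm), giving 7.72. Among the measured compounds shown here, compound 2 `CC1(C)N=C(N)N=C(N)N1c1ccc(OCc2cccc(S(=O)(=O)F)c2Cl)c(Cl)c1` gives 7.49 in this assay, and the only recorded step, a number 0.23 log units lower from compound 1 to compound 2 (within the scatter), shows that adding a chlorine to that ring hardly moved the number. Compound 3 `CC1(C)N=C(N)N=C(N)N1c1ccc(OCc2cc(S(=O)(=O)F)ccc2Cl)c(Cl)c1` differs from compound 1 by chloro in place of hydrogen on an aromatic carbon. For the measured compounds named here, since the one comparable step stayed within the scatter, compound 3 is expected to stay close to compound 1, with a number 0.17 log units lower from compound 1 to compound 3 (within the scatter). Compound 3 is thus estimated at 7.55 in this assay, within the range 7.1 to 8.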

Compound 3, logarithm of the reciprocal of the active concentration, log(1/C): 7.38
Compound 3: the middle estimate sits 0.17 log units above what was measured; measured number inside the range.
By their numbers in this assay, from the lowest: compounds 3, 2 and 1 (each within the scatter of the next, the first and the last beyond it).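

Chloro in place of hydrogen, ortho to a large group and para to a fluorosulfonyl group, gives the only step so far beyond the scatter in this assay (a number 0.34 log units lower from compound 1 to compound 3 (beyond the scatter)). The drop is modest, and compound 2 and compound 3 stay within the scatter of each other, so their two chlorine placements cannot be told apart. Nothing measured here explains this step. From the compounds shown here alone, whether a methoxy group or an amine at this position would keep the number of compound 1 remains open.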